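The source may hold more compounds than are shown below. What is called first, only, known or untested is meant among the compounds shown, and "the series" means these compounds.

Compound 1, `COc1cccc(OC)c1C(=O)Nc1c[nH]nc1C(=O)NC1CCN(Cc2ccccc2)C1`: 38000 nM
Compound 2, `COc1cccc(OC)c1C(=O)Nc1c[nH]nc1C(=O)NCCN1CCCC1`: > 50000 nM

In an ADME assay on MRC5 cells (Homo sapiens) for inhibition, with a stated time of 72 h (a higher number here means that more compound is needed for the effect, a lower number that less compound is needed), compound 1 gives 38000 nM. For compound 2 only a limit is reported in this assay, > 50000 nM, so no number is known for it. Compound 2 is one of the values that sit at the limit of > 50000 nM in this assay, at which 1 of the 2 values shown sits. Compound 1 and compound 2 differ in more than one place, so their values are not a single step; together they show only that both need a large amount of compound for the effect in this assay.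

Compound 3, `COC(=O)c1n[nH]cc1NC(=O)c1c(OC)cccc1OC`, has not yet been measured. Compared with compound 2 the change is: methoxy in place of (2-(pyrrolidin-1-yl)ethyl)amino on a carbonyl carbon. Within the data shown here, no measured step is available to guide this, so the expectation rests on the weak values of compound 1 and compound 2 alone. The expected step is a number no higher from compound 2 to compound 3 (the limit leaves the size open), none beyond the usual scatter. Compound 3 is expected to give about 50000 nM, within a range from 15000 nM to 150000 nM, and it may again come back only as a limit in this assay.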

Compound 3, half-maximal effective concentration: > 50000 nM
Compound 3: a limit, no number; the forecaster's own chance of this, stated with the estimate: 60%; the middle value lies on the limit itself.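

Compound 2 and compound 3 are both reported only as limits, so no step can be read between them: the limit of > 50000 nM in this assay, at which 2 of the 3 values shown sit.

Still open, on these data alone, is how much of either compound this assay would need for the effect, and so whether methoxy in place of (2-(pyrrolidin-1-yl)ethyl)amino on a carbonyl carbon changes the value at all.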